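This account rests on a few compounds, and the source may have more. Where it says the series, first, only, none or still open, it means among the compounds named here.

Measured so far in a functional assay on Huh-7 cells (Homo sapiens) for cytotoxicity, read by MTT assay, with a stated time of 3 days; a lower number here means that less compound is tolerated, a higher number that more compound is tolerated:

- compound 1 `[N-]=[N+]=NCc1ncnc2c1ncn2[C@@H]1O[C@H](CO)[C@@H](O)[C@H]1O`: > 250000 nM, a limit
- compound 2 `OC[C@H]1O[C@@H](n2cnc3c(CSc4ccccn4)ncnc32)[C@H](O)[C@@H]1O`: > 100000 nM, a limit
- compound 3 `O=c1ccn(Cc2ncnc3c2ncn3[C@@H]2O[C@H](CO)[C@@H](O)[C@H]2O)cc1`: > 100000 nM, a limit

None of these compounds has given a number, and the values sit at the limit of > 100000 nM in this assay, at which 2 of the 3 values shown sit, and at the limit of > 250000 nM in this assay, at which 1 of the 3 values shown sits. Compound 2 therefore stands at a limit, > 100000 nM, and its place relative to the others cannot be read.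

The next compound is compound 4 `OC[C@H]1O[C@@H](n2cnc3c(COc4ccccn4)ncnc32)[C@H](O)[C@@H]1O`, which has (pyridin-2-yl)oxy in place of (pyridin-2-yl)sulfanyl on a saturated chain carbon bound to an aromatic carbon.

Among the measured compounds shown here, three measured steps bear on this change. The closest is a step that the two limits leave unreadable from compound 2 to compound 3, since it also replaces the (pyridin-2-yl)sulfanyl group with a ring group containing oxygen. The other two are a step that the two limits leave unreadable from compound 1 to compound 2 and a step that the two limits leave unreadable from compound 1 to compound 3. None of the three has a readable size, so they set no size for the new step, and no step beyond the usual scatter is expected in this assay.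

Compound 3 also stays at a limit, > 100000 nM, and on that basis compound 4 is expected to stay at a limit too. The expected change is a step that the limit leaves unreadable from compound 2 to compound 4. For compound 4 the estimate is 120000 nM, with an expected range from 50000 nM to 250000 nM.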

Compound 4, half-maximal cytotoxic concentration: > 250000 nM
Compound 4 gave a limit, no number (the forecaster's own chance of this, stated with the estimate: 85%); middle value at least 2.0-fold (0.31 log units) away from the limit.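

In this assay compound 4 gives > 250000 nM, a limit and not a number. With compound 1, compound 2 and compound 3 also standing at limits, none of the steps to compound 4 can be read. The compounds shown leave open at what concentration any of them becomes cytotoxic, and whether (pyridin-2-yl)oxy and (pyridin-2-yl)sulfanyl differ at all.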